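The source may hold more compounds than are shown below. What is called first, only, known or untested is meant among the compounds shown, and "the series" means these compounds.

Measured compounds and their values:

Compound 1, `COc1cc2c(=O)c(C(=O)c3ccc(C)cc3)cn(CCCc3ccccc3)c2cc1OC`: "not active" (no number reported)
Compound 2, `COc1cc2c(=O)c(C(=O)OCc3ccc(Cl)cc3)cn(Cc3ccccc3)c2cc1OC`: 28300 nM
Compound 3, `CN1CCN(c2cc3c(cc2F)c(=O)c(NC(=O)NCc2ccccc2)cn3Cc2ccccc2)CC1`: "not active" (no number reported)

All three were tested in an ADME assay on Huh-7 cells (Homo sapiens) for cytotoxicity; a lower number here means a stronger inhibitor of growth, a higher number a weaker inhibitor of growth. Compound 1 gives "not active" (no number reported) in this assay, so no single number stands for it. Compound 3 likewise gives "not active" (no number reported) in this assay. Only compound 2 returns a number, 28300 nM, which is a weak effect on cell growth. Within the data shown here, compound 1 therefore stands among the entries without a number, and no measured step connects it to any other compound.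

Compound 4, `COc1cc2c(=O)c(C(=O)c3ccc(C)cc3)cn(Cc3ccc(N)cc3)c2cc1OC`, differs from compound 1 in one place: 4-aminophenyl in place of phenethyl on a saturated chain carbon bound to an aromatic nitrogen. Among the measured compounds shown here, no measured step links the two, so the expectation rests on compound 1 alone. The shared core, the two methoxy groups and the ketone to the methylphenyl ring all stay in place. The step in this assay is expected to be small, within the usual scatter, and most likely compound 4 will again return no number. Should a number appear, compound 4 is estimated at 45000 nM, within a range of 15000 nM to 120000 nM.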

Compound 4, concentration for 50% growth inhibition: "not active" (no number reported)
The entry for compound 4 holds no number; the estimate stays without a comparison.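

In this assay compound 1 and compound 4 are both reported as not active with no number, so no step can be read between them. Going by these compounds, how far the change from 3-phenylpropyl to 4-aminobenzyl moves growth inhibition stays open. No further data here bear on this result.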